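Benzylamine aryl swap on the diamino core

The compounds below may be only part of what the source reports. "The series", "measured", "known", "first", "only" and "open" are said of these compounds alone.

Compound 1, `Nc1cc(N)c2nc(-c3ccccc3)c(Oc3ccc(Cl)c(Cl)c3)nc2c1`, in a functional assay on RPMI8266 cells (Homo sapiens) for inhibition, read by sulforhodamine B assay, with a stated time of 48 h (a higher number here means a weaker inhibitor of growth, a lower number a stronger inhibitor of growth), gives only a limit, < 100000 nM. Compound 2, `CCOC(=O)[C@H](CCC(=O)O)NC(=O)c1ccc(CNc2nc3cc(N)cc(N)c3nc2-c2ccccc2)cc1`, in this assay also gives only a limit, < 100000 nM. Compound 3, `Nc1cc(N)c2nc(-c3ccccc3)c(NCc3ccc(Cl)c(Cl)c3)nc2c1`, in this assay gives 3720 nM.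

Among the measured compounds shown here, compound 3 thus stands as the single compound with a number; the other two sit at the limit of < 100000 nM in this assay, at which 2 of the 3 values shown sit, so no ordering against them can be drawn. Compound 4, `COc1ccc(CNc2nc3cc(N)cc(N)c3nc2-c2ccccc2)cc1`, differs from compound 3 by 4-methoxyphenyl in place of 3,4-dichlorophenyl on a saturated chain carbon bound to a nitrogen on an aromatic ring. For the measured compounds named here, no measured pair isolates this change, so the step is set from compound 3 alone: a modest weakening of growth inhibition is expected, a 2.2-fold higher number from compound 3 to compound 4 (0.33 log units; beyond the scatter), though with wide uncertainty. For compound 4 the expected value in this assay is 8000 nM, with a range from 2500 nM to 30000 nM.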

Compound 4, concentration for total growth inhibition: 15800 nM
The estimate for compound 4 lay 2.0-fold (0.30 log units) below the measured number, and the stated range covers the measured number.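

Among the compounds shown here, the step at this position is readable for the first time: in this assay, 4-methoxyphenyl in place of 3,4-dichlorophenyl on the saturated chain carbon gives a 4.2-fold higher number from compound 3 to compound 4 (0.63 log units; beyond the scatter). Growth inhibition therefore depends on the aryl group carried there, though this rests on one pair only. Nothing at hand gives a cause for this step.

On these data alone, the separate parts played by the chlorines and the methoxy stay open, as would be tested by an unsubstituted phenyl or a 4-chlorophenyl. Compound 1 and compound 2 give only limits and cannot be placed: the limit of < 100000 nM in this assay, at which 2 of the 4 values shown sit.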